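The compounds below may be only part of what the source reports. "The series", "measured", "known", "first", "only" and "open" are said of these compounds alone.

Measured so far:
compound 1 `COc1ccc([C@H]2CC(c3cc4ccccc4oc3=O)=NN2c2ccccc2)cc1` gives 24.8%
compound 2 `COc1cccc([C@H]2CC(c3cc4ccccc4oc3=O)=NN2c2ccccc2)c1` gives 38.3%

Both were tested in a functional assay on the whole organism (strain albino) for inhibition, with Rattus norvegicus as the target, read by paw edema, with stated times of 1 h and 2 h, at a dose of 200 mg/kg by the oral route; on this read-out lower numbers stand for less inhibition and higher numbers for more inhibition at the one dose given (going by the name of the read-out). Compound 2 stands highest of the two numbers; its nearest neighbour is compound 1, reached by the step of a number 13.5 percentage points higher from compound 1 to compound 2 (beyond the scatter). Compound 3 `O=c1oc2ccccc2cc1C1=NN(c2ccccc2)[C@@H](c2ccc(F)cc2)C1` is not yet measured. It differs from compound 2 by 4-fluorophenyl in place of 3-methoxyphenyl on a saturated ring carbon. Among the measured compounds shown here, the only measured step, a number 13.5 percentage points higher from compound 1 to compound 2 (beyond the scatter), exchanges one methoxyphenyl for another and says nothing about fluorine, so it bears on this change only loosely. Compound 1, which bears 4-methoxyphenyl, gives 24.8%, a faint hint that compound 3 may sit lower. For compound 3 the expected step is a number 7.3 percentage points lower from compound 2 to compound 3 (within the scatter). Compound 3 is therefore estimated at 31%, within 18% to 45%.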

Compound 3, a percentage reported as inhibition, in the whole organism at one dose (the size of the read-out at that dose, not a potency): 44.9%
For compound 3 the middle estimate is 13.9 percentage points below the measured one; the measured number falls inside the stated range.
By their numbers in this assay, from the lowest: compound 1; then compounds 2 and 3 (each within the scatter of the next).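

In this assay, 4-fluorophenyl in place of 3-methoxyphenyl on the saturated ring carbon gives a number 6.6 percentage points higher from compound 2 to compound 3 (within the scatter) and so does not separate these two groups. Fluoro in place of methoxy on an aromatic carbon gives a number 20.1 percentage points higher from compound 1 to compound 3 (beyond the scatter) and shows that, on this ring, a methoxy group is not required for inhibition and that fluoro reads better than the methoxy of compound 1. Nothing available explains either step. Still open, from the compounds shown here alone, is how a plain phenyl, 4-chlorophenyl or 4-aminophenyl group would read on this carbon. Going by these compounds, a carboxylic acid on this ring is equally open.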